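Hydrazone carbamate series: removal of a phenolic hydroxy

The compounds below may be only part of what the source reports. "The series", "measured", "known", "first", "only" and "open" are said of these compounds alone.

Three compounds of this series have been run in a functional assay on cells (Mus musculus) for cytotoxicity, read by MTT assay, with a stated time of 24 h, tested at 10 uM; a higher number here means a stronger effect of the compound at the concentration tested, a lower number a weaker effect. Compound 1 `COc1cc(/C=N/NC(=O)OCc2ccccc2)cc(OC)c1O` gives 69%. Compound 2 `COc1cc(/C=N/NC(=O)c2ccncc2)cc(OC)c1OC`, which carries a different acyl part on the hydrazone, gives 4%. Compound 3 `COc1cc(/C=N/NC(=O)OCc2ccccc2)cc(O)c1O` gives 57% and so stands second of the three: nearest to compound 1, which lies higher by a step beyond the scatter, and far from compound 2, whose number is lower by a step well beyond it. For the measured compounds named here, the one single-point step so far, a number 12 percentage points lower from compound 1 to compound 3 (beyond the scatter), was a modest lowering.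

Compound 4 `COc1cc(/C=N/NC(=O)OCc2ccccc2)ccc1O` is the next point on this path. (hydrogen in place of hydroxy on an aromatic carbon).

Going by the values given here, only the step from compound 1 to compound 3 bears on this change, and only loosely: it traded methyl for hydrogen on an oxygen, whereas here a hydroxy is taken off the ring altogether. Among the compounds with values here, no measured pair shows the loss of a whole oxygen substituent. Within the data shown here, with the one related step modest, a modest movement is expected in this assay, and its direction is not settled by the data; a small lowering or no change beyond the scatter is the working assumption, giving an expected step of a number 2 percentage points lower from compound 3 to compound 4 (within the scatter).

Compound 4 is therefore estimated at 55%, within a range from 40% to 70%.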

Compound 4, a percentage reported as activity, at one concentration (the size of the read-out at that concentration, not a potency): 73%
For compound 4 the middle estimate is 18 percentage points below the measured one, outside the stated range (above it).
By their numbers in this assay, from the lowest: compound 2; then compound 3; then compounds 1 and 4 (each within the scatter of the next).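

In this assay, for the compounds shown here, removing the hydroxy from the aromatic carbon ortho to a hydroxy group gives a number 16 percentage points higher from compound 3 to compound 4 (beyond the scatter), the first upward single-point step and the opposite direction to the lowering seen in a number 12 percentage points lower from compound 1 to compound 3 (beyond the scatter) on the way to the catechol-type pattern of two hydroxy groups. At the same position, hydrogen in place of methoxy gives a number 4 percentage points higher from compound 1 to compound 4 (within the scatter), so hydrogen and methoxy cannot be told apart here, and among the three carbamates only the hydroxy at this position goes with a lower number. No measured evidence at hand bears on the reason for this behaviour.

On these data alone, whether an amine or a chlorine atom at this position would group with hydrogen and methoxy or with hydroxy remains open, as does the role of the hydroxy group that compound 1, compound 3 and compound 4 all share. Also open, as far as these compounds go, is whether the same order holds with the acyl part of compound 2, which differs from these three in more than one place and so offers no comparison at this position.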